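A few compounds are considered here, and "the series" means these few. Any claim that something is new, unique, unknown or untested is made for them only; others in the source may bear on it.

Series notes, step from compound 3 to compound 4.

In a functional assay for activation of Alpha-1A adrenergic receptor (Homo sapiens), read by calcium flux (a higher number here means that more compound is needed for the effect, a lower number that less compound is needed), compound 3 `Cc1ccc(-c2ccccc2NCC2=NCCN2)o1` gives 2.69 nM, the lowest of the three numbers measured. Compound 1 `c1ccc(-c2cnco2)c(NCC2=NCCN2)c1` gives 17.4 nM and compound 2 `Cc1nc(-c2ccccc2NCC2=NCCN2)co1` gives 324 nM; the measured steps of a 6.5-fold lower number from compound 1 to compound 3 (0.81 log units; beyond the scatter) and a 120-fold lower number from compound 2 to compound 3 (2.08 log units; beyond the scatter) show that what sits at this position moves the number over a wide range. Compound 4 `CO/N=C/c1ccccc1NCC1=NCCN1` carries a group of 4 heavy atoms (2 carbon, 1 nitrogen, 1 oxygen; no ring) in place of a group of 6 heavy atoms (5 carbon, 1 oxygen; one five-membered aromatic ring with 1 hetero atom), on an aromatic carbon. Among the measured compounds shown here, no measured step covers a change from a five-membered aromatic ring to a group without a ring, so the direction rests only on compound 3 holding the lowest number; a higher number is expected, of the size of an 11-fold higher number from compound 3 to compound 4 (1.05 log units; beyond the scatter). Compound 4 is thus estimated at 30 nM, with a range from 5 nM to 200 nM.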

Compound 4, half-maximal effective concentration: 51.3 nM
Compound 4: middle estimate off by 1.7-fold (0.23 log units), on the low side; the range from low to high includes it.
By their numbers in this assay, from the lowest: compound 3; then compound 1; then compound 4; then compound 2.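

In this assay, the ringless group of compound 4 falls inside the span set by the five-membered aromatic rings, so a ring at this position is not needed for a number in that span. The change goes in both directions, depending on the ring replaced: a 6.3-fold lower number from compound 2 to compound 4 (0.80 log units; beyond the scatter), yet a 2.9-fold higher number from compound 1 to compound 4 (0.47 log units; beyond the scatter) and a 19-fold higher number from compound 3 to compound 4 (1.28 log units; beyond the scatter). Having a ring therefore does not by itself place a compound on either side of compound 4.

Nothing available explains these differences. Still open, going by these compounds, is where an amine or a longer carbon chain on this aromatic carbon would fall.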